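The source may hold more compounds than are shown below. What is called first, only, known or untested is meant among the compounds shown, and "the series" means these compounds.

Measured in an ADME assay on HeLa cells (Homo sapiens) for cytotoxicity, read by MTT assay; on this read-out higher numbers stand for weaker inhibition and lower numbers for stronger inhibition:
- compound 1 `COC(=O)CNC(=O)CCC(=O)Oc1ccc(C[C@H]2C(=O)OC[C@@H]2Cc2ccc(OC)c(OC)c2)cc1OC` gives 179000 nM
- compound 2 `COc1ccc(C[C@H]2COC(=O)[C@@H]2Cc2ccc(OCC(=O)N3CCCCC3)c(OC)c2)cc1OC` gives 293000 nM
- compound 3 `COc1ccc(C[C@H]2COC(=O)[C@@H]2Cc2ccc(OCC(=O)N3CCCC3)c(OC)c2)cc1OC` gives >= 600000 nM

Within the data shown here, compound 1 and compound 2 are the only two with true numbers, and they lie within the scatter of each other. Compound 3 reached only a limit of the assay, >= 600000 nM.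

Compound 4 `COC(=O)[C@@H](NC(=O)CCC(=O)Oc1ccc(C[C@H]2C(=O)OC[C@@H]2Cc2ccc(OC)c(OC)c2)cc1OC)c1c[nH]c2ccccc12` keeps the rest of compound 1 and changes one spot: 1H-indol-3-yl in place of hydrogen on a saturated chain carbon bound to an amide-type nitrogen and a carbonyl carbon. Among the measured compounds shown here, no measured step touches this saturated chain carbon. The closest guides replace the whole group on an oxygen on an aromatic ring, and they give only a sense of scale. They are a 1.6-fold higher number from compound 1 to compound 2 (0.21 log units; within the scatter) and an at least 3.3-fold higher number from compound 1 to compound 3 (0.52 log units; beyond the scatter). Even these larger swaps are small steps, so in this assay no clear step in either direction is expected for this single addition. The estimated change is a 1.2-fold lower number from compound 1 to compound 4 (0.08 log units; within the scatter), which would stay within the scatter. For compound 4 the expected value is 150000 nM, with an estimated range of 50000 nM to 400000 nM.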

Compound 4, half-maximal inhibitory concentration: >= 600000 nM
Compound 4: a limit, no number; the forecaster's own chance of this, stated with the estimate: 10%; middle value at least 4.0-fold (0.60 log units) from the limit.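

Among these compounds, this is the first view of the saturated chain carbon bound to an amide-type nitrogen and a carbonyl carbon: in this assay, 1H-indol-3-yl in place of hydrogen there gives an at least 3.3-fold higher number from compound 1 to compound 4 (0.52 log units; beyond the scatter). This carbon therefore matters in this assay, since one addition, with the rest of compound 1 unchanged, moves the number upward beyond the scatter, towards weaker inhibition. The full size of the step cannot be read, since compound 4 gives a limit and not a number: the limit of >= 600000 nM in this assay, at which 2 of the 4 values shown sit.

Going by these compounds, it remains open whether this rise needs 1H-indol-3-yl in particular or would follow from other groups on this carbon, such as a methyl, a phenyl, an amine or a carboxylic acid. Also open, on these data alone, is whether a smaller group here would leave the number within the scatter of compound 1.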